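Ketone to methoxyanilide on the shared trimethoxyphenyl-triazole core

The compounds below may be only part of what the source reports. "The series", "measured", "known", "first", "only" and "open" are said of these compounds alone.

Among the compounds with values here, compound 3 `COc1cc(-c2nnc(SCC(=O)c3ccccc3F)n2N)cc(OC)c1OC` sits highest of the two numbers known in a functional assay on HeLa cells (Homo sapiens) for antiproliferative activity, read by MTT assay, with a stated time of 48 h (a higher number here means a weaker inhibitor, a lower number a stronger inhibitor), where compound 3 gives 80100 nM. Compound 1 `COc1cc(-c2nnc(SCC(=O)c3ccc(C(F)(F)F)cc3)n2N)cc(OC)c1OC` gives 3380 nM. Compound 2 `COc1cc(-c2nnc(SCC(=O)c3ccc(F)c(F)c3)n2N)cc(OC)c1OC` reaches only a limit of the assay, > 100000 nM. Compound 4 `COc1cccc(NC(=O)CSc2nnc(-c3cc(OC)c(OC)c(OC)c3)n2N)c1` differs from compound 3 by (3-methoxyphenyl)amino in place of 2-fluorophenyl on a carbonyl carbon. Every measured step also swaps the group on that carbonyl carbon: a 24-fold higher number from compound 1 to compound 3 (1.37 log units; beyond the scatter) and an at least 29-fold higher number from compound 1 to compound 2 (1.47 log units; beyond the scatter) were large, whereas an at least 1.2-fold lower number from compound 2 to compound 3 (0.09 log units; that floor lies within the scatter) stayed within the scatter. Going by these compounds, these steps show that the group on the carbonyl carbon can move the number a great deal, but none of them exchanges a fluorinated phenyl for an amino-linked ring, so the direction remains open. Compound 4 is therefore expected near 50000 nM, within 8000 nM to 150000 nM, an estimated step of a 1.6-fold lower number from compound 3 to compound 4 (0.20 log units; within the scatter), with a real chance that only a limit is reported.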

Compound 4, half-maximal inhibitory concentration: 4020 nM
The estimate for compound 4 lay 12-fold (1.09 log units) above the measured number; the whole stated range lies above it.
By their numbers in this assay, from the lowest: compounds 1 and 4 (each within the scatter of the next); then compound 3. At a limit, above all of these: compound 2.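

On the carbonyl carbon, an amino-linked ring can give a much lower number than a fluorinated phenyl: (3-methoxyphenyl)amino in place of 2-fluorophenyl gives a 20-fold lower number from compound 3 to compound 4 (1.30 log units; beyond the scatter). Against 4-(trifluoromethyl)phenyl, the same exchange gives a 1.2-fold higher number from compound 1 to compound 4 (0.08 log units; within the scatter), so compounds 1 and 4 cannot be told apart. Against 3,4-difluorophenyl, it gives an at least 24-fold lower number from compound 2 to compound 4 (1.39 log units; beyond the scatter), a floor only because compound 2 stands at a limit: the limit of > 100000 nM in this assay, at which 1 of the 4 values shown sits.

With one amino-linked ring shown, the share of its methoxy group remains unknown. A plain phenylamino group or a piperidine ring on that carbonyl carbon would be needed to separate the methoxy group from the amino link.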